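Benzoxazole-type series: single-point cytotoxicity notes, next step

The compounds below may be only part of what the source reports. "The series", "measured", "known", "first", "only" and "open" are said of these compounds alone.

Measured so far:
Compound 1 `O=C(Nc1ccc(Sc2nc3ccccc3s2)c(Cl)c1)c1cccc(Br)c1O`, 12000 nM
Compound 2 `O=S(=O)(Nc1ccc(-c2nc3cc(NS(=O)(=O)c4ccccc4Cl)ccc3o2)cc1)c1ccccc1Cl`, 12000 nM
Compound 3 `COc1ccc(S(=O)(=O)Nc2ccc3oc(-c4ccc(NS(=O)(=O)c5cc(Br)ccc5OC)cc4)nc3c2)cc1`, 12000 nM

In a functional assay on HCT-116 cells (Homo sapiens) for cytotoxicity, read by resazurin assay, with a stated time of 48 h (a higher number here means that more compound is needed for the effect, a lower number that less compound is needed), compound 1 gives 12000 nM. In this assay compound 2 gives 12000 nM and compound 3 gives 12000 nM. Compound 3 stands level with compound 1 and compound 2 at the digits shown; none of the three is separated from the others beyond the scatter, so no ranking among them can be drawn, and no change between any pair of them is established.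

Compound 4 `COc1ccc(S(=O)(=O)Nc2ccc3oc(-c4ccc(NC(=O)C5CCN(C(C)=O)CC5)cc4)nc3c2)cc1` is the next compound to be measured in this assay. Relative to compound 3 the change is (1-acetylpiperidin-4-yl)carbonyl in place of (5-bromo-2-methoxyphenyl)sulfonyl on a nitrogen on an aromatic ring. Among the compounds with values here, no measured pair shares this kind of change, so there is no measured step to lean on; what the data show is that three rather different right-hand groups all land on the same value. On that basis the step from compound 3 to compound 4 is expected to be no change at the digits printed from compound 3 to compound 4 (within the scatter), that is, none beyond the scatter. For compound 4 the value in this assay is estimated at 12000 nM, within 5000 nM to 30000 nM.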

Compound 4, half-maximal effective concentration: 15000 nM
Compound 4: the middle estimate sits 1.3-fold (0.10 log units) below what was measured; low and high end bracket the measured number.
By their numbers in this assay, from the lowest: compounds 1, 2, 3 and 4 (each within the scatter of the next).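

Within the data shown here, this is the first comparison of two compounds that differ in one place: on a nitrogen on an aromatic ring, (1-acetylpiperidin-4-yl)carbonyl in place of (5-bromo-2-methoxyphenyl)sulfonyl gives in this assay a 1.3-fold higher number from compound 3 to compound 4 (0.10 log units; within the scatter) and so separates the two groups by nothing beyond the scatter. This position therefore tolerates the loss of the six-membered aromatic ring of carbon only and its bromine, and the entry of a six-membered non-aromatic ring with a hetero atom, without a established shift in the number. No data at hand offer an explanation for this flat result.

From the compounds shown here alone, whether a free amine or a carboxylic acid at this nitrogen would move the number beyond the scatter remains open. Also open, going by these compounds, is whether any change to the other sulfonyl group of compound 4 would do so.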